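The compounds below may be only part of what the source reports. "The series", "measured", "known", "first", "only" and "open" are said of these compounds alone.

Measured so far:
compound 1, `CN1C(=S)[C@@H](NC(=O)c2nc(Cc3ccccc3)n(CCCCCC#N)n2)COc2ccccc21`: 3830 nM
compound 2, `CN1C(=S)[C@@H](NC(=O)c2nc(Cc3ccccc3)n(CC3COC3)n2)COc2ccccc21`: 2830 nM
compound 3, `CN1C(=S)[C@@H](NC(=O)c2nc(Cc3ccccc3)n(C3CCN(C(=O)OC(C)(C)C)C3)n2)COc2ccccc21`: > 10000 nM

In a functional assay on HT-29 cells (Homo sapiens) for inhibition, read by luminescence and CellTiter-Glo, with a stated time of 24 h (a higher number here means that more compound is needed for the effect, a lower number that less compound is needed), compound 1 gives 3830 nM, the highest of the two numbers shown. Compound 2 stands close to it, with a 1.4-fold lower number from compound 1 to compound 2 (0.13 log units; within the scatter). Compound 3 reaches only a limit of the assay, > 10000 nM, the one such limit in this set (the limit of > 10000 nM in this assay, at which 1 of the 3 values shown sits).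

Compound 4, `CN1C(=S)[C@@H](NC(=O)c2nc(Cc3ccccc3)n(-c3ncccn3)n2)COc2ccccc21`, has not yet been measured. It differs from compound 1 by pyrimidin-2-yl in place of 5-cyanopentyl on an aromatic nitrogen. For the measured compounds named here, two measured steps concern the same aromatic nitrogen: the swap to the oxetane ring in compound 2 gave a 1.4-fold lower number from compound 1 to compound 2 (0.13 log units; within the scatter), whereas the larger carbamate-bearing ring of compound 3 gave an at least 2.6-fold higher number from compound 1 to compound 3 (0.41 log units; beyond the scatter). Neither step tests an aromatic substituent on that nitrogen, so the new group lies outside the measured range. Since the change in compound 2 left the number essentially unchanged, as shown by a 1.4-fold lower number from compound 1 to compound 2 (0.13 log units; within the scatter), while only the much larger group moved it, little shift is expected here. Compound 4 is therefore expected to give about 4500 nM, with a range from 1500 nM to 12000 nM. The expected step for compound 4 is a 1.2-fold higher number from compound 1 to compound 4 (0.07 log units; within the scatter).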

Compound 4, half-maximal effective concentration: 3970 nM
Compound 4: the middle estimate sits 1.1-fold (0.05 log units) above what was measured; measured number inside the range.
By their numbers in this assay, from the lowest: compounds 2, 1 and 4 (each within the scatter of the next). At a limit, above all of these: compound 3.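

In this assay, an aromatic ring placed directly on this aromatic nitrogen is tolerated as well as the open chain or the oxetane-bearing group: the change to pyrimidin-2-yl gives a 1.0-fold higher number from compound 1 to compound 4 (0.02 log units; within the scatter), and the comparison with the (oxetan-3-yl)methyl group gives a 1.4-fold higher number from compound 2 to compound 4 (0.15 log units; within the scatter). The step of an at least 2.5-fold lower number from compound 3 to compound 4 (0.40 log units; beyond the scatter) shows that a ring on this nitrogen is not in itself what sets the carbamate-bearing group apart. Compound 3 gives a limit of the assay, not a number: the limit of > 10000 nM in this assay, at which 1 of the 4 values shown sits.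

The compounds shown leave open whether a plain phenyl ring in place of pyrimidin-2-yl, or an amine or carboxylic acid carried on that ring, would move the number. They also leave open whether the free amine of the ring in compound 3 would behave as the carbamate does.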